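Amide variation in the diaryl urea series

The source may hold more compounds than are shown below. What is called first, only, known or untested is meant among the compounds shown, and "the series" means these compounds.

Compound 1 `CNC(=O)c1cccc(-c2ccc(NC(=O)Nc3ccc(Cl)c(C(F)(F)F)c3)cc2)c1` gives 39300 nM in a functional assay on KETR3 cells (Homo sapiens) for inhibition, read by MTT assay, with a stated time of 120 h; on this read-out lower numbers stand for stronger inhibition and higher numbers for weaker inhibition. For compound 2 `O=C(CCc1ccc(NC(=O)Nc2ccc(Cl)c(C(F)(F)F)c2)cc1)NC1CCC1` this assay reports only a limit, > 50000 nM. Among the measured compounds shown here, the one measured step with a single change, an at least 1.2-fold higher number from compound 1 to compound 2 (0.10 log units; that floor lies within the scatter), sits at the limit of > 50000 nM in this assay, at which 2 of the 3 values shown sit. For compound 3 `C/C(=C\C(=O)N1CC(C)OC(C)C1)c1ccc(NC(=O)Nc2ccc(Cl)c(C(F)(F)F)c2)cc1` this assay again reports only a limit, > 50000 nM, so compound 3 stands at the limit with no finite number. Compound 4 `C/C(=C\C(=O)NC(C)c1ccccc1)c1ccc(NC(=O)Nc2ccc(Cl)c(C(F)(F)F)c2)cc1` differs from compound 3 by (1-phenylethyl)amino in place of 2,6-dimethylmorpholin-4-yl on a carbonyl carbon. For the measured compounds named here, no measured step touches this part of the molecule; the single step measured lies elsewhere and stays within the scatter, and the limit of > 50000 nM in this assay, at which 2 of the 3 values shown sit, shows most values at the limit. The step of a number no higher from compound 3 to compound 4 (the limit leaves the size open) is expected to stay within the scatter. Compound 4 is estimated at 50000 nM, within 15000 nM to 150000 nM, and is most likely reported only as a limit.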

Compound 4, half-maximal inhibitory concentration: > 50000 nM
Compound 4 gave a limit, no number (the forecaster's own chance of this, stated with the estimate: 70%); the middle value lies on the limit itself.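

Compound 3 and compound 4 both stand only as limits in this assay, so no step between them can be read: the limit of > 50000 nM in this assay, at which 3 of the 4 values shown sit.

The compounds shown leave open whether changing this amide can bring a finite number in this assay.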